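The compounds below may be only part of what the source reports. "The series", "measured", "known", "first", "only" and "open" are said of these compounds alone.

Measured compounds in a functional assay on K562 cells (Homo sapiens) for inhibition, read by sulforhodamine B assay, with a stated time of 48 h, tested at 10 uM; on this read-out lower numbers stand for a stronger effect and higher numbers for a weaker effect at the one concentration tested:

- compound 1 `O=C(Nc1cccc(-n2cc(-c3ccncc3)c(-c3cc(O)cc(Cl)c3)n2)c1)Nc1ccc(Cl)c(C(F)(F)F)c1`: 5.24%
- compound 2 `O=C(Nc1cccc(-n2cc(-c3ccncc3)c(-c3cc(O)cc(Cl)c3)n2)c1)Nc1ccc(Cl)c(Cl)c1`: 1.06%
- compound 3 `COc1cc(Cl)cc(-c2nn(-c3cccc(NC(=O)Nc4ccc(Cl)c(C(F)(F)F)c4)c3)cc2-c2ccncc2)c1`: 8.93%

All three numbers sit low in this assay, and they sit close together. Compound 3 gives the highest of the three, yet no gap separates it from the others beyond the scatter: the step of a number 3.7 percentage points higher from compound 1 to compound 3 (within the scatter) is small, and the two values of compound 3 and compound 2 likewise show only a small gap. The other shown step, a number 4.2 percentage points lower from compound 1 to compound 2 (within the scatter), is also within the scatter.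

Compound 4 `COc1cc(Cl)cc(-c2nn(-c3cccc(NC(=O)Nc4cccc(C(F)(F)F)c4)c3)cc2-c2ccncc2)c1` differs from compound 3 by hydrogen in place of chloro on an aromatic carbon. For the measured compounds named here, no measured pair shows this change. The nearest bearing comes from the same ring: the step from compound 1 to compound 2 exchanges the group that neighbours the trifluoromethyl in compound 4's parent, and that exchange moved nothing beyond the scatter. Nor did the methyl for hydrogen step from compound 1 to compound 3. On that footing the expected step for compound 4 is a number 1.1 percentage points higher from compound 3 to compound 4 (within the scatter), that is, none beyond the scatter, with the true value of compound 4 expected at 10%, within a range from 2% to 25%.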

Compound 4, a percentage reported as activity, at one concentration (the size of the read-out at that concentration, not a potency): 7.61%
Compound 4: middle estimate off by 2.4 percentage points, on the high side, within the range that was stated.
By their numbers in this assay, from the lowest: compounds 2, 1, 4 and 3 (each within the scatter of the next).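

In this assay, for the compounds shown here, the step from the 4-chloro-3-(trifluoromethyl)phenyl group to the 3-(trifluoromethyl)phenyl group gives a number 1.3 percentage points lower from compound 3 to compound 4 (within the scatter) and is the first direct reading of this position, on an aromatic carbon ortho to a trifluoromethyl group and para to a large group. The earlier steps shown here changed the trifluoromethyl group or the oxygen on the other aromatic ring and left this chloro in place, whereas this pair shows that, with the methoxy group present, hydrogen can stand in for chloro with no change beyond the scatter at the one concentration tested. No measurement at hand offers an explanation for this result.

Still open, from the compounds shown here alone, is whether a larger or charged group at this position, such as an amine or a carboxylic acid, would leave the read-out equally undisturbed, and whether the same chloro-to-hydrogen exchange holds on compound 1, which carries the free hydroxyl group. A single concentration also gives the size of the read-out and not a potency, so any difference in potency between compound 3 and compound 4 remains unresolved.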